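The source may hold more compounds than are shown below. What is called first, only, known or untested is meant among the compounds shown, and "the series" means these compounds.

Working notes on the series. Two compounds have numbers in a functional assay on A-431 cells (Homo sapiens) for cytotoxicity, read by MTT assay, with a stated time of 48 h; a higher number here means a weaker inhibitor, a lower number a stronger inhibitor. Compound 1 `CCCCCCCCCCCCCCCCCCNC(=O)[C@@H](N)[C@@H](C)O` gives 21300 nM in this assay. Compound 2 `CCCCCCCCNC(=O)[C@@H](NC(=O)c1ccco1)[C@@H](C)O` gives 64500 nM in this assay, the highest of the two numbers; the nearest number is that of compound 1, and the gap between the two lies beyond the scatter. Among the compounds with values here, no step between two measured compounds that differ in a single place is available, so the series gives no direct guide for the change now considered.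

Compound 3 `CCCCCCCCNC(=O)[C@@H](NC(=O)/C=C/c1ccccc1)[C@@H](C)O` is not yet measured. It differs from compound 2 in one place: 2-phenylethenyl in place of furan-2-yl on a carbonyl carbon. Within the data shown here, with no comparable step among the measured compounds, the expected step from compound 2 to compound 3 is a 1.6-fold lower number from compound 2 to compound 3 (0.21 log units; within the scatter), a modest move toward a lower number, not clearly beyond the scatter. For compound 3 the estimate in this assay is 40000 nM, with a range from 15000 nM to 110000 nM.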

Compound 3, half-maximal inhibitory concentration: 36000 nM
For compound 3 the middle estimate is 1.1-fold (0.05 log units) above the measured one; the range from low to high includes it.
By their numbers in this assay, from the lowest: compounds 1, 3 and 2 (each within the scatter of the next, the first and the last beyond it).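

In this assay, the series now has its first single-place comparison, a 1.8-fold lower number from compound 2 to compound 3 (0.25 log units; within the scatter). On a carbonyl carbon whose other neighbour is an amide-type nitrogen, 2-phenylethenyl and furan-2-yl cannot be told apart in this assay, even though the swap replaces a five-membered aromatic ring with 1 hetero atom by a six-membered all-carbon aromatic ring and adds a double bond outside the ring. No measurement at hand bears on why the two groups read alike.

Open, going by these compounds, is whether an amine or a carboxylic acid in place of furan-2-yl on this carbonyl carbon would give a step beyond the scatter. Also open, on these data alone, is what a longer chain does alone with this group held fixed, since compound 1 differs from compound 2 in more than one place.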